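The source may report more compounds than this note shows. Statements on the series, on what has been measured and on what is new or still open speak of the compounds shown alone.

Working notes on the series. Compound 1 `CC(C)(C)OC(=O)/C=C1/C(=O)Nc2ccccc21` gives 94.5% in a functional assay on HL-60 cells (Homo sapiens) for inhibition, read by CCK-8 assay, with a stated time of 72 h, tested at 20 uM; a lower number here means less inhibition of growth, a higher number more inhibition of growth at the concentration tested. Compound 2 `CC(C)(C)OC(=O)/C=C1/C(=O)N(Cc2ccccc2)c2ccccc21` gives 91.7% in this assay. Among the measured compounds shown here, of the two numbers known so far, compound 1 sits next to compound 2, and the step of a number 2.8 percentage points lower from compound 1 to compound 2 (within the scatter) lies within the scatter, so the two compounds are not separated by this read-out.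

Compound 3 `COc1ccc2c(c1)NC(=O)/C2=C/C(=O)OC(C)(C)C` is still to be measured in this assay. It differs from compound 1 by methoxy in place of hydrogen on an aromatic carbon. For the measured compounds named here, the single measured step, from compound 1 to compound 2, concerns the amide-type nitrogen, not the aromatic ring, so it does not bear directly on this change; it shows only that a substitution elsewhere on the shared core left the number within the scatter. Going by the values given here, no step on the aromatic ring has been measured. The expected step is therefore a number 3.5 percentage points lower from compound 1 to compound 3 (within the scatter), none beyond the scatter. Compound 3 is estimated at 91%, with a range from 78% to 98%.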

Compound 3, percent growth inhibition at one concentration: 91.6%
Estimate against measurement, compound 3: 0.6 percentage points below; low and high end bracket the measured number.
By their numbers in this assay, from the lowest: compounds 3, 2 and 1 (each within the scatter of the next).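

Methoxy in place of hydrogen on an aromatic carbon, meta to a fused ring and para to a fused ring, gives the first step on the aromatic ring of the shared core: a number 2.9 percentage points lower from compound 1 to compound 3 (within the scatter) in this assay at this carbon. This position therefore carries methoxy without separating the two compounds by this read-out, and a change on the aromatic ring now stands with the change on the amide-type nitrogen as a step within the scatter. No measurement at hand bears on the reason for this result.

Open, going by these compounds, is whether an amine or a carboxylic acid on this same aromatic carbon would also stay within the scatter of compound 1. Also open, on these data alone, is whether methoxy on another carbon of the ring would do the same.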